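Acyl Swap on a Fixed Hydrazone Series

The compounds below may be only part of what the source reports. "The series", "measured", "known", "first", "only" and "open" are said of these compounds alone.

Measured so far:
compound 1, `CN(C(=O)NC(=O)c1ccc(F)c(F)c1)c1nc(C(F)(F)F)c(C(=O)N/N=C/c2cccc(C(F)(F)F)c2)s1`: 5.6 ug/mL
compound 2, `CN(C(=O)NC(=O)c1ccc(F)c(F)c1)c1nc(C(F)(F)F)c(C(=O)N/N=C/c2cc(C(F)(F)F)cc(C(F)(F)F)c2)s1`: 5.47 ug/mL

In a functional assay on HepG2 cells (Homo sapiens) for inhibition, read by MTT assay, with a stated time of 72 h (on this read-out higher numbers stand for weaker inhibition and lower numbers for stronger inhibition), compound 1 gives 5.6 ug/mL and compound 2 gives 5.47 ug/mL. Among the measured compounds shown here, the one measured step, a 1.0-fold lower number from compound 1 to compound 2 (0.01 log units; within the scatter), sits within the scatter, so compound 2 and compound 1 stand at one level and no order between them is claimed. Compound 3, `CN(C(=O)NC(=O)c1ccc(Cl)cc1Cl)c1nc(C(F)(F)F)c(C(=O)N/N=C/c2cc(C(F)(F)F)cc(C(F)(F)F)c2)s1`, differs from compound 2 by 2,4-dichlorophenyl in place of 3,4-difluorophenyl on a carbonyl carbon. For the measured compounds named here, no measured step touches the group on that carbonyl carbon, so the two values give no ground for a shift in either direction; the step of a 1.0-fold higher number from compound 2 to compound 3 (0.00 log units; within the scatter) is expected to stay within the scatter. For compound 3 a value of 5.5 ug/mL is expected, between 2.5 ug/mL and 12 ug/mL.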

Compound 3, half-maximal inhibitory concentration: > 100 ug/mL
Compound 3 was reported as a limit; the forecaster's own chance of this, stated with the estimate: 5%; middle value at least 18-fold (1.25 log units) from the limit.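

Among the compounds shown here, the group on the carbonyl carbon is the first place where a change registers in this assay: 2,4-dichlorophenyl in place of 3,4-difluorophenyl gives an at least 18-fold higher number from compound 2 to compound 3 (1.26 log units; beyond the scatter). This position is therefore not indifferent, whereas the added trifluoromethyl on the aromatic carbon stayed within the scatter. The reading for compound 3 is a limit, not a number: the limit of > 100 ug/mL in this assay, at which 1 of the 3 values shown sits.

As far as these compounds go, how far compound 3 lies past that limit stays open. Also open, from the compounds shown here alone, is what 3,4-dichlorophenyl on that carbonyl carbon gives, which would part the halogen from its placement.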